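Cytotoxicity notes: phenylsulfonyl in place of methylsulfonyl

The source may report more compounds than this note shows. Statements on the series, on what has been measured and on what is new or still open speak of the compounds shown alone.

Compound 3 `CS(=O)(=O)N(CCCCCCN1C[C@H](O)[C@@H](O)[C@H](O)[C@H]1CO)C1CCCCC1` is tested in an ADME assay on Huh-7 cells (Homo sapiens) for cytotoxicity, read by MTT assay; on this read-out higher numbers stand for lower toxicity in this test and lower numbers for higher toxicity in this test. In this assay compound 3 is reported only as a limit, > 500000 nM. Compound 1 `CC(C)(C)C(=O)N(CCCCCCN1C[C@H](O)[C@@H](O)[C@H](O)[C@H]1CO)C1CCCCC1` gives 500000 nM in this assay. Compound 2 `O=C(c1cc(F)c(F)cc1F)N(CCCCCCN1C[C@H](O)[C@@H](O)[C@H](O)[C@H]1CO)C1CCCCC1` in this assay is likewise a limit, > 500000 nM. Compound 3 thus stands where two of the three values sit, (the limit of > 500000 nM in this assay, at which 2 of the 3 values shown sit). Compound 4 `O=S(=O)(c1ccccc1)N(CCCCCCN1C[C@H](O)[C@@H](O)[C@H](O)[C@H]1CO)C1CCCCC1` differs from compound 3 by phenyl in place of methyl on a sulfonyl sulfur. Going by the values given here, the steps that bear on this tail position are a number no lower from compound 1 to compound 3 (the limit leaves the size open), a number no lower from compound 1 to compound 2 (the limit leaves the size open) and a step that the two limits leave unreadable from compound 2 to compound 3; none has a readable size, and all end at or near the limit. No step beyond the scatter is therefore expected in this assay. Compound 4 is estimated at 500000 nM, range 150000 nM to 600000 nM, with an expected step of a number no higher from compound 3 to compound 4 (the limit leaves the size open).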

Compound 4, half-maximal cytotoxic concentration: 280000 nM
The estimate for compound 4 lay 1.8-fold (0.25 log units) above the measured number, within the range that was stated.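

In this assay the phenylsulfonyl compound 4 gives a readable number on the sulfonyl side of the series, where the methylsulfonyl compound 3 offers only a limit. Phenyl on the sulfonyl sulfur gives an at least 1.7-fold lower number from compound 3 to compound 4 (0.25 log units; that floor lies within the scatter), and the comparisons with the carbonyl compounds give an at least 1.7-fold lower number from compound 2 to compound 4 (0.25 log units; that floor lies within the scatter) and a 1.8-fold lower number from compound 1 to compound 4 (0.25 log units; within the scatter), so all three read within the scatter, the first two only as floors. Compound 4 sits off the limit: the limit of > 500000 nM in this assay, at which 2 of the 4 values shown sit.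

As far as these compounds go, the true size of the first two steps stays open. So does whether a carboxylic acid or an amine on the phenyl ring would move the number beyond the scatter.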